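Swapping the terminal ring: from fluoropyridine to isothiazole

The source may hold more compounds than are shown below. What is called first, only, known or untested is meant among the compounds shown, and "the series" means these compounds.

Measured so far:
- compound 1 `CCC(C)(C)Cc1c[nH]c(CCc2ccc(-n3ncnn3)cc2)n1`: 422 nM
- compound 2 `CCC(C)(C)Cc1c[nH]c(CCc2ccc(-c3cnccn3)cc2)n1`: 431 nM
- compound 3 `CCC(C)(C)Cc1c[nH]c(CCc2ccc(-c3ccc(F)cn3)cc2)n1`: 66 nM

In a functional assay on HEK293 cells for agonist activity at Bombesin receptor subtype-3 (Homo sapiens), read by luminescence and calcium flux, with a stated time of 10 min (a higher number here means that more compound is needed for the effect, a lower number that less compound is needed), compound 3 gives the lowest number of the three, with a 6.4-fold lower number from compound 1 to compound 3 (0.81 log units; beyond the scatter) and a 6.5-fold lower number from compound 2 to compound 3 (0.81 log units; beyond the scatter) both beyond the scatter, while compound 1 and compound 2 sit within the scatter of each other. Compound 4 `CCC(C)(C)Cc1c[nH]c(CCc2ccc(-c3cnsc3)cc2)n1` differs from compound 3 in one place: 1,2-thiazol-4-yl in place of 5-fluoropyridin-2-yl on an aromatic carbon. The two steps that bear on this change are those into compound 3, which show that the 5-fluoropyridin-2-yl group lowered the number by a modest amount compared with either of the other two terminal groups. Since compound 4 gives up that group for another heteroaryl ring, the expectation is that the number moves back toward those of compound 1 and compound 2, so a modest rise, a 4.5-fold higher number from compound 3 to compound 4 (0.66 log units; beyond the scatter), is expected. Compound 4 is therefore estimated at 300 nM, within a range of 100 nM to 900 nM.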

Compound 4, half-maximal effective concentration: 44 nM
Compound 4: the middle estimate sits 6.8-fold (0.83 log units) above what was measured, and the stated range ends above it.
By their numbers in this assay, from the lowest: compounds 4 and 3 (each within the scatter of the next); then compounds 1 and 2 (each within the scatter of the next).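

In this assay, the low number of compound 3 proves not to need a six-membered ring or a fluorine: the 1,2-thiazol-4-yl group, a five-membered aromatic ring containing sulfur, gives a 1.5-fold lower number from compound 3 to compound 4 (0.18 log units; within the scatter), so these two terminal groups cannot be told apart here. Both stay well clear of the other two groups, as the 1,2-thiazol-4-yl group gives a 9.8-fold lower number from compound 2 to compound 4 (0.99 log units; beyond the scatter) against pyrazin-2-yl and a 9.6-fold lower number from compound 1 to compound 4 (0.98 log units; beyond the scatter) against 2H-tetrazol-2-yl. Nothing measured here explains why these terminal rings differ.

From the compounds shown here alone, it remains open which atoms of the 1,2-thiazol-4-yl group matter, and whether a plain phenyl or a thiophen-3-yl ring on this aromatic carbon would give a similarly low number. Also open, going by these compounds, is how an amine or a carboxylic acid on the terminal ring would change the result.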